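Side-Chain Variation in a Melanocortin Receptor 4 Binding Series

The source may report more compounds than this note shows. Statements on the series, on what has been measured and on what is new or still open speak of the compounds shown alone.

Measured so far:
compound 1, `NC(COCc1ccccc1)c1cc(F)ccc1N1CCN(C(=O)CCc2ccc(Cl)cc2Cl)CC1`, 1000 nM
compound 2, `CCC(C)[C@H](NCCN)c1cc(C(F)(F)F)ccc1N1CCN(C(=O)CCc2ccc(Cl)cc2Cl)CC1`, 56 nM

In an assay on HEK293 cells for displacement of a labelled ligand from Melanocortin receptor 4 (Homo sapiens) (on this read-out lower numbers stand for stronger inhibition and higher numbers for weaker inhibition), compound 2 gives 56 nM, the lowest of the two numbers recorded; compound 1 gives a higher number, and that gap lies beyond the usual scatter. Compound 3, `COCCN[C@@H](CC(C)C)c1cc(C(F)(F)F)ccc1N1CCN(C(=O)CCc2ccc(Cl)cc2Cl)CC1`, has not yet been measured. It differs from compound 2 in one place: 1-((2-methoxyethyl)amino)-3-methylbutyl in place of 1-((2-aminoethyl)amino)-2-methylbutyl on an aromatic carbon. The group that leaves carries two hydrogen-bond donors and two nitrogens; the group that enters carries one hydrogen-bond donor, one nitrogen and one oxygen. For the measured compounds named here, no measured pair in this set shows this change, so its effect cannot be read directly from the data. The step from compound 2 to compound 3 is expected to be a moderate increase in the number, a 3.6-fold higher number from compound 2 to compound 3 (0.55 log units; beyond the scatter). Compound 3 is therefore estimated at 200 nM, with a likely range from 60 nM to 800 nM.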

Compound 3, inhibition constant: 620 nM
For compound 3 the middle estimate is 3.1-fold (0.49 log units) below the measured one; the range from low to high includes it.
By their numbers in this assay, from the lowest: compound 2; then compounds 3 and 1 (each within the scatter of the next).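

In this assay, for the compounds shown here, 1-((2-methoxyethyl)amino)-3-methylbutyl in place of 1-((2-aminoethyl)amino)-2-methylbutyl gives an 11-fold higher number from compound 2 to compound 3 (1.04 log units; beyond the scatter), the first reading in this set of a change in one place, and it shows that the side chain on this aromatic carbon can move the number substantially. The change alters two parts of the side chain at once, the aminoethyl end and the branching of the butyl chain, so this single step cannot be divided between them. Nothing available explains the size of the step.

Going by these compounds, it remains open which part carries the step, a question that the 2-aminoethyl group on the 3-methylbutyl chain, or the 2-methoxyethyl group on the 2-methylbutyl chain, would address. On these data alone, how a 2-hydroxyethyl group or a longer 3-aminopropyl chain on the same nitrogen would read also remains open.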